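The source may report more compounds than this note shows. Statements on the series, on what has been measured and on what is new or still open speak of the compounds shown alone.

Of the compounds shown here, three sharing one core have been tested in a functional assay on A549 cells (Homo sapiens) for cytotoxicity, read by MTT assay; on this read-out higher numbers stand for weaker inhibition and lower numbers for stronger inhibition. Compound 1 `CCOC(=O)c1oc2cc(OC)cc(OC)c2c1C` is reported as "not active" (no number reported) in this assay. Compound 3 `CCOC(=O)c1oc2c(C#N)c(OC)cc(OC)c2c1C` likewise comes out as "not active" (no number reported) in this assay. For compound 2 `CCOC(=O)c1oc2c(Br)c(OC)cc(OC)c2c1C` only a limit of the assay is given, > 87400 nM in this assay, so no single number stands for it. Compound 2 thus sits at the edge of the numbers shown, the point described by the limit of > 87400 nM in this assay, at which 1 of the 3 values shown sits, while the two other entries carry no number at all. Compound 4 `COc1cc(OC)c2c(C)c(C=O)oc2c1Br` has not yet been measured. It differs from compound 2 by one change: hydrogen in place of ethoxy on a carbonyl carbon, so the ethoxycarbonyl of compound 2 becomes formyl. No step between two measured compounds is available, so the size of this change cannot be read from anything shown. The expectation rests on compound 2, whose result was the limit > 87400 nM. The step from compound 2 to compound 4 is expected to be a step that the limit leaves unreadable from compound 2 to compound 4, nothing beyond the scatter. Compound 4 is therefore estimated at 100000 nM, within 30000 nM to 300000 nM, and most probably reported again only as a limit.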

Compound 4, half-maximal inhibitory concentration: 49500 nM
Beside the measured number, compound 4's estimate is 2.0-fold (0.31 log units) above it; low and high end bracket the measured number.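

Hydrogen in place of ethoxy on a carbonyl carbon, which turns the ethoxycarbonyl into formyl, yields the first plain number of the set: in this assay compound 4 gives 49500 nM. The change amounts to an at least 1.7-fold lower number from compound 2 to compound 4 (0.24 log units; that floor lies within the scatter), so this floor alone cannot be told apart from the scatter of repeated measurements. The true size of the step may be larger, because compound 2 is known only through a limit: the limit of > 87400 nM in this assay, at which 1 of the 4 values shown sits.

Steps involving compound 1 or compound 3 cannot be read, since neither carries a number, so it stays open whether formyl would give a number without the bromine of compound 4. Also open, going by these compounds, is how a carboxylic acid, a primary amide or a longer ester chain on that same carbonyl carbon would read.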